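Changing the carbonyl substituent: compound 3 to compound 4

This account rests on a few compounds, and the source may have more. Where it says the series, first, only, none or still open, it means among the compounds named here.

Of the compounds shown here, three sharing one core have been measured in a functional assay on PC-3 cells (Homo sapiens) for inhibition, read by sulforhodamine B assay, with a stated time of 72 h; a higher number here means a weaker inhibitor, a lower number a stronger inhibitor. Compound 1 (`CC1CCN(C(=O)c2c(N)sc(-c3ccc(Cl)cc3)c2-c2ccc(Cl)cc2)CC1`) gives 5750 nM, compound 2 (`Nc1sc(-c2ccc(Cl)cc2)c(-c2ccc(Cl)cc2)c1C(=O)N1CCOCC1`) gives 11700 nM and compound 3 (`Nc1sc(-c2ccc(Cl)cc2)c(-c2ccc(Cl)cc2)c1C(=O)N1CCC(=O)CC1=O`) gives 9230 nM. The value of compound 3 thus falls inside the narrow span set by the other two and lies within the scatter of each.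

Compound 4 (`COc1ccc(CNC(=O)c2c(N)sc(-c3ccc(Cl)cc3)c2-c2ccc(Cl)cc2)cc1`) has (4-methoxybenzyl)amino in place of 2,4-dioxopiperidin-1-yl on a carbonyl carbon. The three measured steps all change the group at this same place. The swap of groups on the carbonyl carbon gives a 2.0-fold higher number from compound 1 to compound 2 (0.31 log units; beyond the scatter), which is modest. The two steps that involve compound 3 are smaller, at a 1.6-fold higher number from compound 1 to compound 3 (0.21 log units; within the scatter) and a 1.3-fold lower number from compound 2 to compound 3 (0.10 log units; within the scatter).

Among the compounds with values here, these steps offer only an indirect guide, since no measured compound carries (4-methoxybenzyl)amino or the amide hydrogen it brings. Changes at this place have so far moved this assay very little, so no step beyond the scatter is expected, and the estimated step is a 1.3-fold lower number from compound 3 to compound 4 (0.12 log units; within the scatter). The direction of that small step remains uncertain. The estimated value for compound 4 is 7000 nM, with an expected range from 2500 nM to 18000 nM.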

Compound 4, half-maximal inhibitory concentration: 29500 nM
Estimate against measurement, compound 4: 4.2-fold (0.62 log units) below, outside the stated range (above it).
By their numbers in this assay, from the lowest: compounds 1, 3 and 2 (each within the scatter of the next, the first and the last beyond it); then compound 4.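

In this assay, the group on the carbonyl carbon proved able to move the number beyond the scatter, with a 3.2-fold higher number from compound 3 to compound 4 (0.50 log units; beyond the scatter), a 2.5-fold higher number from compound 2 to compound 4 (0.40 log units; beyond the scatter) and a 5.1-fold higher number from compound 1 to compound 4 (0.71 log units; beyond the scatter). Compound 1, compound 2 and compound 3 carry 4-methylpiperidin-1-yl, morpholin-4-yl and 2,4-dioxopiperidin-1-yl, and their narrow span had suggested that this place tolerates change, but compound 4 is the weakest of the four, so that tolerance does not extend to (4-methoxybenzyl)amino. No independent measurement is available to explain why this group raised the number.

The compounds shown leave open whether the rise follows the amide hydrogen, the aromatic ring or the methoxy group, since all three enter together in this one change. A plain benzylamino group, which lacks the methoxy, and a small group such as methylamino, which keeps the amide hydrogen but has no aromatic ring, would begin to separate these features in this assay.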